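This account rests on a few compounds, and the source may have more. Where it says the series, first, only, none or still open, it means among the compounds named here.

Compound 1, `Nc1ncn(CCC2(N)OC(=O)C(OCc3ccccc3)=C2OCc2ccccc2)c(=O)n1`, in a functional assay on HepG2 cells (Homo sapiens) for inhibition, read by MTT assay, with a stated time of 72 h (on this read-out higher numbers stand for weaker inhibition and lower numbers for stronger inhibition), gives > 100000 nM.
Compound 2, `O=C1O/C(=C\Cn2ncc(=O)[nH]c2=O)C(OCc2ccccc2)=C1OCc1ccccc1`, in this assay gives 41300 nM.

The value for compound 1 is a limit of this assay and not a number; compound 1 therefore stands at the limit of > 100000 nM in this assay, at which 1 of the 2 values shown sits. Compound 2 is built on an unsaturated core and carries a different heterocycle, and of the two only compound 2 returns a measured number in this assay. Compound 3, `NC1(CCn2ncc(=O)[nH]c2=O)OC(=O)C(OCc2ccccc2)=C1OCc1ccccc1`, has not yet been measured. It differs from compound 1 by a group of 8 heavy atoms (3 carbon, 3 nitrogen, 2 oxygen; one six-membered aromatic ring with 3 hetero atoms) in place of a group of 8 heavy atoms (3 carbon, 4 nitrogen, 1 oxygen; one six-membered aromatic ring with 3 hetero atoms), on a saturated chain carbon, two bonds along the chain from a saturated ring carbon. For the measured compounds named here, the heterocycle that enters is the one carried by compound 2, while the saturated core of compound 1 is kept. Going by the values given here, no step between measured compounds is available on which to ground the size of this change. A step of an at least 1.4-fold lower number from compound 1 to compound 3 (0.15 log units; that floor lies within the scatter) is expected, that is, a gain in inhibition beyond the scatter but a modest one, because compound 2 with the same heterocycle on its own core gives only 41300 nM in this assay. Compound 3 is estimated at 70000 nM, within 30000 nM to 150000 nM, with a real chance that this assay again reports only a limit.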

Compound 3, half-maximal inhibitory concentration: > 100000 nM
Compound 3: a limit, no number; the forecaster's own chance of this, stated with the estimate: 45%; middle value at least 1.4-fold (0.15 log units) from the limit.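

Compound 1 and compound 3 each return only a limit and not a number, so the step between them cannot be read: the limit of > 100000 nM in this assay, at which 2 of the 3 values shown sit.

The compounds shown leave open whether exchanging one heterocycle for the other on the core of compound 1 changes inhibition at all, and in which direction.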